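Swapping the Sulfonyl Group on an Acylsulfonamide Platelet Inhibitor

The source may hold more compounds than are shown below. What is called first, only, known or untested is meant among the compounds shown, and "the series" means these compounds.

Measured so far:
compound 1 `CC1(C(=O)NS(=O)(=O)Cc2ccccc2)CCN(c2nc3c(cc2C#N)C(=O)OC3)CC1` — 6680 nM
compound 2 `CC1OC(=O)c2cc(C#N)c(N3CCC(C(=O)NS(=O)(=O)Cc4ccccc4)C3)nc21` — > 300000 nM

Of the compounds shown here, two have been tested in a functional assay (Platelet, plasma) for inhibition, with Homo sapiens as the target; a higher number here means a weaker inhibitor, a lower number a stronger inhibitor. For the measured compounds named here, compound 1 gives 6680 nM, the only plain number in the set. Compound 2 reaches only > 300000 nM, which is a limit of the assay rather than a number; the evidence here is the limit of > 300000 nM in this assay, at which 1 of the 2 values shown sits. Going by the values given here, compound 2 shares the acylsulfonamide end with compound 1 but differs elsewhere, so no single-point step connects the two.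

The next compound, compound 3 `CC1(C(=O)NS(=O)(=O)c2ccc(Cl)s2)CCN(c2nc3c(cc2C#N)C(=O)OC3)CC1`, is built from compound 1 by one change: 5-chlorothiophen-2-yl in place of benzyl on a sulfonyl sulfur. Among the compounds with values here, no measured pair shows what this kind of swap does in this assay, so the expectation rests on compound 1 alone. A modest gain in potency in this assay seems plausible but far from certain, and a step of roughly a 2.2-fold lower number from compound 1 to compound 3 (0.35 log units; beyond the scatter) is expected, well within a range that also allows no change beyond the scatter. Compound 3 is therefore estimated at 3000 nM, between 800 nM and 15000 nM.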

Compound 3, half-maximal inhibitory concentration: 1640 nM
Compound 3: the middle estimate sits 1.8-fold (0.26 log units) above what was measured; the range from low to high includes it.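

For the compounds shown here, putting 5-chlorothiophen-2-yl in place of benzyl on a sulfonyl sulfur gives a 4.1-fold lower number from compound 1 to compound 3 (0.61 log units; beyond the scatter) in this assay, the first direct reading of what a change at this position does. The position therefore responds to the group placed on it, and the rest of the molecule can stay the same while the number moves beyond the usual scatter. It also shows that benzyl is not needed for this level of inhibition, since a five-membered aromatic ring carrying a chlorine takes its place and gives the lower number, but nothing measured here bears on what lies behind this step.

Still open, from the compounds shown here alone, is whether the thiophene ring or the chlorine accounts for the step: a plain phenyl, an unsubstituted thiophen-2-yl or a 5-methylthiophen-2-yl on the same sulfonyl sulfur would pull these two features apart. Also open, going by these compounds, is whether the same swap would lower the number on the core of compound 2, and how an amine or a carboxylic acid on the new ring would fare in this assay at this position.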